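The source may hold more compounds than are shown below. What is called first, only, known or untested is meant among the compounds shown, and "the series" means these compounds.

Going by the values given here, in a functional assay on the whole organism (strain albino) with Mus musculus as the target, in the maximal electroshock model, with a stated time of 0.5 h (a lower number here means that less compound is needed, a higher number that more compound is needed for the effect), compound 2 (`O=C1c2ccccc2C(=O)N1c1ccccc1Cl`) gives 168 mg/kg and stands highest of the two numbers so far, with compound 1 (`O=C1c2ccccc2C(=O)N1c1ccccc1`) at 66.2 mg/kg on the same scale. Compound 3 (`O=C1c2ccccc2C(=O)N1c1ccccc1F`) has fluoro in place of chloro on an aromatic carbon, ortho to a large group (fluoro in place of chloro on an aromatic carbon). Among the compounds with values here, one measured step bears on this place: a 2.5-fold higher number from compound 1 to compound 2 (0.40 log units; beyond the scatter) (modest in size). Within the data shown here, no fluoro compound has been measured, so a similarly modest step to a lower number is expected in this assay for compound 3. The expected change is a 2.1-fold lower number from compound 2 to compound 3 (0.32 log units; beyond the scatter) in this estimate. For compound 3 the estimated value is 80 mg/kg with 40 mg/kg to 160 mg/kg as the expected range.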

Compound 3, dose for half-maximal effect: > 300 mg/kg
Compound 3 ended at the assay's limit; the forecaster's own chance of this, stated with the estimate: 5%; middle value at least 3.7-fold (0.57 log units) away from the limit.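

In this assay compound 3 carries a limit of the assay and not a number: the limit of > 300 mg/kg in this assay, at which 1 of the 3 values shown sits.

Fluoro in place of hydrogen on this aromatic carbon, ortho to a large group, gives an at least 4.5-fold higher number from compound 1 to compound 3 (0.65 log units; beyond the scatter), so chloro is not the only halogen here that goes with a higher number. Fluoro in place of chloro gives an at least 1.7-fold higher number from compound 2 to compound 3 (0.25 log units; that floor lies within the scatter), so the order of the two halogens remains unsettled.

Open, from the compounds shown here alone, is how a methyl, a methoxy or an amine behaves at this place. Also open, going by these compounds, is whether chloro or fluoro elsewhere on this ring gives the same rise.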